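The source may hold more compounds than are shown below. What is called first, only, known or untested is meant among the compounds shown, and "the series" means these compounds.

Measured compounds in a functional assay on HL-60 cells (Homo sapiens) for inhibition, read by MTT assay, with a stated time of 72 h; a higher number here means a weaker inhibitor, a lower number a stronger inhibitor:
- compound 1, `C=C(C)c1ccc(N2CCN(C(=O)c3oc(C)nc3-c3ccccc3)CC2)cc1`, reported as "not active" (no number reported)
- compound 2, `Cc1nc(-c2ccccc2Cl)c(C(=O)N2CCN(c3cccc(Cl)c3)CC2)o1`, 132 nM
- compound 3, `Cc1ccc(C)c(N2CCN(C(=O)c3oc(C)nc3-c3ccccc3Cl)CC2)c1`, whose value is a limit of the assay, > 1000 nM

Compound 1 thus stands without a number; it is simply recorded as inactive in this assay. The unmeasured compound 4, `Cc1nc(-c2ccccc2)c(C(=O)N2CCN(c3ccc(Cl)c(Cl)c3)CC2)o1`, differs from compound 1 by one change: 3,4-dichlorophenyl in place of 4-(1-methylethenyl)phenyl on an amine nitrogen in a ring. Going by the values given here, the only measured step, an at least 7.5-fold higher number from compound 2 to compound 3 (0.87 log units; beyond the scatter), also changes the group on this ring nitrogen, and one value there is a limit (the limit of > 1000 nM in this assay, at which 1 of the 3 values shown sits). That step shows a chlorine-bearing phenyl on this nitrogen giving the lower number, so compound 4 is expected to reach a measurable value in this assay, estimated at 400 nM, between 100 nM and 3000 nM.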

Compound 4, half-maximal inhibitory concentration: 124 nM
Estimate against measurement, compound 4: 3.2-fold (0.51 log units) above; the measured number falls inside the stated range.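

The change from compound 1 to compound 4 cannot be read as a step: compound 1 is recorded only as "not active" (no number reported). Still open, on these data alone, is how 3,4-dichlorophenyl, with all else unchanged, compares with the other groups on this ring nitrogen.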